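The source may report more compounds than this note shows. Statements on the series, on what has been measured and on what is new or still open speak of the compounds shown alone.

Measured so far in an ADME assay on BJ cells (Homo sapiens) for cytotoxicity, with a stated time of 72 h; on this read-out lower numbers stand for an effect already at smaller amounts and higher numbers for an effect only at larger amounts of compound:

- compound 1 `COc1ccc(NC(=O)Nc2cc(C)nc3ccccc23)cc1F`: 26000 nM
- compound 2 `Cc1cc(NC(=O)Nc2ccccc2C(F)(F)F)c2ccccc2n1`: a limit of the assay, > 25000 nM
- compound 3 `Cc1cc(NC(=O)Nc2ccc(N)cc2)c2ccccc2n1`: a limit of the assay, > 25000 nM

Compound 2 stands at the limit of this assay, so only a bound and no number is known for it. The picture across the three compounds is thin, since (the limit of > 25000 nM in this assay, at which 2 of the 3 values shown sit). Compound 1 does return a number, and that number sits in the same weak region as the two limits. Among the compounds with values here, no pair of measured compounds differs in a single place, so no measured step is available to lean on.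

Compound 4 `Cc1cc(NC(=O)Nc2ccccc2[N+](=O)[O-])c2ccccc2n1` is the next compound to be read in this assay. It differs from compound 2 by nitro in place of trifluoromethyl on an aromatic carbon.

Nothing measured here ties this exchange to a shift in cytotoxicity, and the weak reading of all three measured compounds gives no reason to expect one. The step is expected to be a step that the limit leaves unreadable from compound 2 to compound 4, that is, none beyond the scatter, with a fair chance that this assay again reports only a limit. Compound 4 is estimated at 30000 nM, within a range from 12000 nM to 80000 nM.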

Compound 4, half-maximal effective concentration: > 25000 nM
Compound 4 was reported as a limit (the forecaster's own chance of this, stated with the estimate: 60%); the middle value lies beyond the limit too.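

Compound 2 and compound 4 both stand at a limit of the assay, so no step between them can be read: the limit of > 25000 nM in this assay, at which 3 of the 4 values shown sit.

The compounds shown leave open whether nitro in place of trifluoromethyl on an aromatic carbon changes cytotoxicity at all.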